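Swapping the Ketone Side Chain for a Cyclopropylmethyl Ester

The compounds below may be only part of what the source reports. "The series", "measured", "known", "first", "only" and "open" are said of these compounds alone.

Three close analogues share one core and differ only in the aromatic ring attached to a saturated ring carbon. Compound 1 `CC1=C(C(=O)CC(C)C)C(c2ccoc2)NC(=O)N1` carries a furan-3-yl group, compound 2 `CC1=C(C(=O)CC(C)C)C(c2cccs2)NC(=O)N1` a thiophen-2-yl group, and compound 3 `CC1=C(C(=O)CC(C)C)C(c2ccsc2)NC(=O)N1` a thiophen-3-yl group. In an assay on membranes from HeLa cells for displacement of a labelled ligand from adenosine receptor A3 (Homo sapiens), read by scintillation counting, with a stated time of 180 min, tested at 1 uM (a lower number here means less inhibition, a higher number more inhibition at the concentration tested (going by the name of the read-out)), compound 1 gives 18%, compound 2 gives 18%, and compound 3 gives 14%. The changes among them are small: no change at the digits printed from compound 1 to compound 2 (within the scatter), a number 4 percentage points lower from compound 1 to compound 3 (within the scatter) and a number 4 percentage points lower from compound 2 to compound 3 (within the scatter). Compound 3 therefore sits among three numbers that cannot be told apart, and the three aromatic groups leave this assay essentially unmoved.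

Compound 4 `CC1=C(C(=O)OCC2CC2)C(c2ccsc2)NC(=O)N1` keeps the thiophen-3-yl group of compound 3 but alters the other substituent: cyclopropylmethoxy in place of isobutyl on a carbonyl carbon. Within the data shown here, none of the three measured steps touches this carbonyl carbon; all of them vary the aromatic ring, so there is no measured step that speaks to the new change. Among the measured compounds shown here, the only guide is the low and flat level shared by compound 1, compound 2 and compound 3. On these data alone, on that basis compound 4 is expected to show a step of a number 1 percentage points higher from compound 3 to compound 4 (within the scatter) in this assay, with considerable uncertainty because the change itself is untested. Compound 4 is estimated at 15%, in a range from 0% to 38%.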

Compound 4, a percentage reported as inhibition, at one concentration (the size of the read-out at that concentration, not a potency): 3%
The estimate for compound 4 lay 12 percentage points above the measured number; low and high end bracket the measured number.
By their numbers in this assay, from the lowest: compound 4; then compounds 3, 1 and 2 (each within the scatter of the next).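

Where swapping the aromatic ring had left this assay unmoved, the substituent on the carbonyl carbon proves able to shift the read-out: cyclopropylmethoxy in place of isobutyl gives a number 11 percentage points lower from compound 3 to compound 4 (beyond the scatter), a modest step but the only one shown that lies beyond the scatter. Among these compounds, the change brings in an oxygen, a hydrogen-bond acceptor and a three-membered carbon ring all at once, so this single step cannot separate their contributions, and it has been seen only with the thiophen-3-yl group in place. Nothing shown gives a reason for the lower number.

The compounds shown leave open whether cyclopropylmethoxy would lower the number in the same way alongside the furan-3-yl or thiophen-2-yl group, since the step rests on one pair of compounds. They also leave open how the read-out would respond to other groups on the same carbonyl carbon, such as methoxy, which would test the oxygen without the three-membered ring, cyclopropylmethyl, which would test the ring without the oxygen, or an amine.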